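The source may hold more compounds than are shown below. What is called first, only, known or untested is meant among the compounds shown, and "the series" means these compounds.

Measured so far:
- compound 1 `CC(C(=O)NCc1ccc(C(F)(F)F)nc1NS(=O)(=O)c1ccccc1)c1ccc(NS(C)(=O)=O)c(F)c1` — an assay on CHO cells for displacement of a labelled ligand from transient receptor potential cation channel subfamily V member 1 (Homo sapiens), read by scintillation counting, with a stated time of 60 min; a higher number here means a weaker inhibitor, a lower number a stronger inhibitor: "active" (no number reported)
- compound 2 `CC(C(=O)NCc1ccc(C(F)(F)F)nc1N(CC1CCCCC1)S(=O)(=O)c1ccccc1)c1ccc(NS(C)(=O)=O)c(F)c1` — this assay: 2.3 nM

Compound 1 has no single number; in this assay compound 1 is recorded only as "active" (no number reported), so its exact standing is open. Among the measured compounds shown here, compound 2, the one measured neighbour, gives 2.3 nM in this assay.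

Compound 3 `CC(C(=O)NCc1ccc(C(F)(F)F)nc1N(Cc1ccccc1)S(C)(=O)=O)c1ccc(NS(C)(=O)=O)c(F)c1` differs from compound 1 in one place: benzyl(methylsulfonyl)amino in place of (phenylsulfonyl)amino on an aromatic carbon

For the measured compounds named here, no measured pair covers this change, so the size of the step is unknown; it is expected to be small to moderate, likely within the scatter or a little weaker than compound 2. For compound 3 in this assay an inhibition constant near 6 nM is expected, in the range 1.5 nM to 30 nM.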

Compound 3, inhibition constant: 101 nM
Compound 3: the middle estimate sits 17-fold (1.23 log units) below what was measured; measured number outside the range, above it.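

Compound 1 carries no number in this assay and compound 3 gives 101 nM so no step can be read between them. As far as these compounds go, what the change from (phenylsulfonyl)amino to benzyl(methylsulfonyl)amino does to the value stays open, and no available evidence bears on the result.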